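Side-chain ring swaps on the shared core

This account rests on a few compounds, and the source may have more. Where it says the series, first, only, none or still open, it means among the compounds named here.

Among the measured compounds shown here, compound 2 `CC(C)C(Cc1noc(=O)[nH]1)c1ccc(-c2ccc3cccc(F)c3c2)[nH]c1=O` carries the higher of the two numbers measured so far in an assay on CHO cells for displacement of a labelled ligand from prostaglandin E2 receptor EP3 subtype (Homo sapiens), read by radioligand binding; a lower number here means a stronger inhibitor, a higher number a weaker inhibitor: compound 2 gives 34 nM, whereas compound 1 `CC(C)C(c1ccc(-c2ccc3cccc(F)c3c2)[nH]c1=O)N1CCCCS1(=O)=O` gives 14 nM. For the measured compounds named here, the one measured step at this position, a 2.4-fold higher number from compound 1 to compound 2 (0.39 log units; beyond the scatter), sets the scale of change that a ring swap on the saturated chain carbon bound to an aromatic carbon and a saturated chain carbon has produced so far. Compound 3 `CC(C)C(/C=C1\CCNC1=O)c1ccc(-c2ccc3cccc(F)c3c2)[nH]c1=O` makes another such swap: a group of 7 heavy atoms (5 carbon, 1 nitrogen, 1 oxygen; one five-membered non-aromatic ring with 1 hetero atom) in place of a group of 7 heavy atoms (3 carbon, 2 nitrogen, 2 oxygen; one five-membered aromatic ring with 3 hetero atoms), on a saturated chain carbon bound to an aromatic carbon and a saturated chain carbon. The five-membered aromatic ring with 3 hetero atoms leaves and a five-membered non-aromatic ring with 1 hetero atom enters, with 1 hydrogen-bond donor present on either side. Going by the values given here, no measured step covers this exchange; the only comparable swap, a 2.4-fold higher number from compound 1 to compound 2 (0.39 log units; beyond the scatter), was modest, so a modest step is expected for a 1.2-fold higher number from compound 2 to compound 3 (0.07 log units; within the scatter), with its direction uncertain. Compound 3 is estimated at 40 nM in this assay, within 10 nM to 160 nM.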

Compound 3, inhibition constant: 2.2 nM
Compound 3: the middle estimate sits 18-fold (1.26 log units) above what was measured; measured number outside the range, below it.
By their numbers in this assay, from the lowest: compound 3; then compound 1; then compound 2.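

In this assay, this place on the saturated chain carbon bound to an aromatic carbon and a saturated chain carbon proves far more sensitive than the earlier comparison indicated: the five-membered non-aromatic ring with 1 hetero atom gives a 15-fold lower number from compound 2 to compound 3 (1.19 log units; beyond the scatter), a large step with the hydrogen-bond donor count the same on both sides. The same group also compares favourably with the six-membered non-aromatic ring with 2 hetero atoms, with a 6.4-fold lower number from compound 1 to compound 3 (0.80 log units; beyond the scatter), so it gives the lowest number of the three groups. No supporting data are available to account for either step.

It remains open whether the ring, its carbonyl or the double bond outside the ring accounts for the change, as these differ together in the compounds shown. On these data alone, how an open-chain amide or a carboxylic acid on the same carbon would compare also remains open.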